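Swapping Fluoro for Trifluoromethyl on the Sulfonyl Aryl Ring

The source may hold more compounds than are shown below. What is called first, only, known or untested is meant among the compounds shown, and "the series" means these compounds.

For the measured compounds named here, compound 2 `O=S(=O)(c1ccc(F)cc1)c1cccc2oc(N3CCNCC3)nc12` gives 64 nM in an assay on HeLa cells for displacement of a labelled ligand from 5-hydroxytryptamine receptor 6 (Homo sapiens) (a higher number here means a weaker inhibitor, a lower number a stronger inhibitor), one of only two numbers, the other being compound 1 `O=S(=O)(c1cccc(F)c1)c1cccc2oc(N3CCNCC3)nc12` at 54 nM, within the scatter of each other. Going by the values given here, the single measured step, a 1.2-fold higher number from compound 1 to compound 2 (0.07 log units; within the scatter), simply shifts a fluoro around the ring. Compound 3 `O=S(=O)(c1ccc(C(F)(F)F)cc1)c1cccc2oc(N3CCNCC3)nc12` differs from compound 2 by trifluoromethyl in place of fluoro on an aromatic carbon. No measured step exchanges a fluoro for a trifluoromethyl, so nothing shown bears directly on this change. Because compound 2 gives 64 nM, compound 3 is expected at 80 nM, ranging from 25 nM to 250 nM. This estimate implies a 1.3-fold higher number from compound 2 to compound 3 (0.10 log units; within the scatter), a step expected to stay within the scatter.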

Compound 3, inhibition constant: 33 nM
Compound 3: the middle estimate sits 2.4-fold (0.38 log units) above what was measured; the range from low to high includes it.
By their numbers in this assay, from the lowest: compounds 3, 1 and 2 (each within the scatter of the next).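

In this assay, the spot para to a large group accepts trifluoromethyl in place of fluoro: the step is a 1.9-fold lower number from compound 2 to compound 3 (0.29 log units; within the scatter), so compound 2 and compound 3 cannot be told apart. Unlike the earlier step, which only moved a fluoro around the ring, this one changes the group itself, and the number stays within the scatter. No measurement here offers an explanation for this result.

Still open, on these data alone, is how an amine, a carboxylic acid or a longer chain would fare at this spot. Also open, as far as these compounds go, is how trifluoromethyl would fare where fluoro sits in compound 1.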